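The source may hold more compounds than are shown below. What is called first, only, known or untested is meant among the compounds shown, and "the series" means these compounds.

Measured so far:
- compound 1, `O=c1c2cnn(-c3ccc(F)cc3)c2ncn1CC1(O)CCN(Cc2ccc(F)cc2)CC1`: "not determined" (no result reported) in an assay on Sf21 cells for inhibition of ubiquitin carboxyl-terminal hydrolase 7 (Homo sapiens), read by spectrophotometry, with stated times of 30 min and 2 h; on this read-out higher numbers stand for weaker inhibition and lower numbers for stronger inhibition
- compound 2, `O=c1c2cnn(-c3ccc(F)cc3)c2ncn1CC1(O)CCN(Cc2ccccc2Br)CC1`: 3100 nM

Among the compounds with values here, compound 2 is the only compound here with a number, so there is nothing to rank it against. Compound 3, `N#Cc1ccccc1CN1CCC(O)(Cn2cnc3c(cnn3-c3ccc(F)cc3)c2=O)CC1`, differs from compound 2 in one place: cyano in place of bromo on an aromatic carbon. Within the data shown here, no pair of measured compounds shows what such a change does, so the expectation rests on compound 2 alone. For compound 3 the step from compound 2 is expected to be small, close to the scatter, with a slight lean toward weaker inhibition: a 1.3-fold higher number from compound 2 to compound 3 (0.11 log units; within the scatter). In this assay compound 3 is estimated at 4000 nM, most likely between 1500 nM and 12000 nM.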

Compound 3, half-maximal inhibitory concentration: 8100 nM
The estimate for compound 3 lay 2.0-fold (0.31 log units) below the measured number; low and high end bracket the measured number.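

In this assay the change is not neutral: there is a 2.6-fold higher number from compound 2 to compound 3 (0.42 log units; beyond the scatter), so inhibition weakens when cyano replaces bromo. Within the data shown here, this gives the first sign that the group on this aromatic carbon, ortho to a large group, affects the result, something a single measured compound could not show. Nothing available here explains the loss.

From the compounds shown here alone, whether other groups would do better or worse on this carbon remains open, for example plain hydrogen, methoxy, an amine or a carboxylic acid. Compound 1 has no reported result, so it adds no comparison.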